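Amide to urea on a pyrazole-bearing antiproliferative series

The source may report more compounds than this note shows. Statements on the series, on what has been measured and on what is new or still open speak of the compounds shown alone.

Compound 1 `CC(=O)c1cc(C(=O)N[C@@H](C)Cn2ccc(-c3cc(F)c(C#N)c(Cl)c3)n2)n[nH]1` and compound 2 `CC(=O)c1cc(C(=O)N[C@H](C)Cn2ccc(-c3cc(F)c(C#N)c(Cl)c3)n2)n[nH]1` share one core and differ only in the configuration drawn at a saturated chain carbon (the fact that compounds 1 and 2 differ only in the configuration as drawn). In a functional assay on LNCaP cells (Homo sapiens) for antiproliferative activity, read by CCK-8 assay, with a stated time of 6 days (on this read-out higher numbers stand for weaker inhibition and lower numbers for stronger inhibition), compound 1 gives 1100 nM, and compound 2 gives 1080 nM; the step of a 1.0-fold lower number from compound 1 to compound 2 (0.01 log units; within the scatter) lies within the scatter, so the two numbers are indistinguishable. Compound 3 `C[C@@H](Cn1ccc(-c2cc(F)c(C#N)c(Cl)c2)n1)NC(=O)Nc1cc(C(C)(C)C)[nH]n1` is not yet measured. It differs from compound 1 by (5-(tert-butyl)-1H-pyrazol-3-yl)amino in place of 5-acetyl-1H-pyrazol-3-yl on a carbonyl carbon. For the measured compounds named here, no measured step touches this kind of change, so the expected step of a 1.1-fold higher number from compound 1 to compound 3 (0.04 log units; within the scatter) for compound 3 is centred near no change, with a wide range. Compound 3 is therefore estimated at 1200 nM (range 250 nM to 6000 nM).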

Compound 3, half-maximal inhibitory concentration: 1630 nM
Compound 3: middle estimate off by 1.4-fold (0.13 log units), on the low side, within the range that was stated.
By their numbers in this assay, from the lowest: compounds 2, 1 and 3 (each within the scatter of the next).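

Replacing 5-acetyl-1H-pyrazol-3-yl on a carbonyl carbon with (5-(tert-butyl)-1H-pyrazol-3-yl)amino turns the amide into a urea, and in this assay this gives a 1.5-fold higher number from compound 1 to compound 3 (0.17 log units; within the scatter). So this place takes a different group, with 10 heavy atoms instead of 8 and no oxygen, without a readable shift in the number. Nothing at hand explains this result.

From the compounds shown here alone, whether a carboxylic acid or an amine in place of the tert-butyl would leave the number as undisturbed remains open. So does whether configuration at the saturated chain carbon is as indifferent in the urea as in the amide.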